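The compounds below may be only part of what the source reports. "The series", "measured", "known", "first", "only" and "open" are said of these compounds alone.

Compounds measured so far:
- compound 1, `NC1=NC2(CCOCC2)N(OCCCOc2cccc(Cl)c2)C(N)=N1`: 520 nM
- compound 2, `NC1=NC2(CCOCC2)N(OCCCOc2ccc(F)cc2)C(N)=N1`: 2380 nM
- compound 3, `NC1=NC2(CCOCC2)N(OCCCOc2ccc(Cl)cc2)C(N)=N1`: 330 nM

In a functional assay on HL-60 cells (Homo sapiens) for antiproliferative activity, read by MTT assay, with a stated time of 72 h (on this read-out lower numbers stand for stronger inhibition and higher numbers for weaker inhibition), compound 3 gives the lowest of the three numbers. Its nearest neighbour is compound 1, and the step of a 1.6-fold lower number from compound 1 to compound 3 (0.20 log units; within the scatter) lies within the scatter, so the two cannot be ranked against each other. Compound 2 is furthest away, and the step of a 7.2-fold lower number from compound 2 to compound 3 (0.86 log units; beyond the scatter) is beyond the scatter.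

Compound 4, `NC1=NC2(CCOCC2)N(OCCCOc2ccccc2Br)C(N)=N1`, is the compound not yet measured. Its difference from compound 3 is 2-bromophenyl in place of 4-chlorophenyl on an oxygen on a saturated carbon. Within the data shown here, two measured steps bear on this change. The move of a chloro from one ring position to another, a 1.6-fold lower number from compound 1 to compound 3 (0.20 log units; within the scatter), changed the number only within the scatter. Exchanging one halogen for another, a 7.2-fold lower number from compound 2 to compound 3 (0.86 log units; beyond the scatter), gave a modest shift. Among the measured compounds shown here, no measured pair shows a bromo or a 2-substituted phenyl, so the expectation rests on these two steps alone. Compound 4 is therefore expected to stay in the same region as compound 3 in this assay, with a step of a 1.5-fold higher number from compound 3 to compound 4 (0.18 log units; within the scatter) expected, a change not clearly beyond the scatter. The estimate for compound 4 is 500 nM, within a range from 150 nM to 1700 nM.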

Compound 4, half-maximal inhibitory concentration: 610 nM
The estimate for compound 4 lay 1.2-fold (0.09 log units) below the measured number, within the range that was stated.
By their numbers in this assay, from the lowest: compounds 3, 1 and 4 (each within the scatter of the next); then compound 2.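

In this assay, the 2-bromophenyl group on this oxygen cannot be told apart from either chlorophenyl group, with a 1.8-fold higher number from compound 3 to compound 4 (0.27 log units; within the scatter) and a 1.2-fold higher number from compound 1 to compound 4 (0.07 log units; within the scatter). The 4-fluorophenyl group alone stands apart, with a 3.9-fold lower number from compound 2 to compound 4 (0.59 log units; beyond the scatter). Among these four compounds, then, a halogen other than chloro and a third substitution pattern on the phenyl ring still leave the number in the same region, and compound 2 is the one that goes against this.

The step to compound 4 exchanges the halogen and moves it in one change, so the share of each stays open, and nothing shown gives a reason for these results. Also open, as far as these compounds go, is whether a phenyl ring carrying a methoxy group or a nitrile, or a longer chain to the phenoxy group, would stay in this region.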